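Third methoxy on compound 3: a step from a limit

This account rests on a few compounds, and the source may have more. Where it says the series, first, only, none or still open, it means among the compounds named here.

In a functional assay on 4T1 cells (Mus musculus) for cytotoxicity, read by MTT assay, with a stated time of 48 h (a lower number here means a stronger inhibitor, a higher number a weaker inhibitor), compound 3 `COc1ccc(OC)c(/C=C/C(=O)/C=C/c2cc3ccccc3nc2Oc2cccc(Cl)c2)c1` is reported only as a limit, > 10000 nM. Compound 2 `COc1ccc(/C=C/C(=O)/C=C/c2cc3ccccc3nc2Oc2cccc(Cl)c2)c(OC)c1` is likewise reported only as a limit, > 10000 nM. The change to compound 4 `COc1cc(OC)c(OC)cc1/C=C/C(=O)/C=C/c1cc2ccccc2nc1Oc1cccc(Cl)c1` is methoxy in place of hydrogen on an aromatic carbon, turning 2,5-dimethoxyphenyl into 2,4,5-trimethoxyphenyl. Within the data shown here, the one measured step that bears on this change, a step that the two limits leave unreadable from compound 2 to compound 3, moves between methoxy patterns but gives no size to carry over. Among the measured compounds shown here, the only number comes from compound 1 `COc1cc(OC)c(OC)cc1/C=C/C(=O)/C=C/c1cc2ccccc2nc1Oc1ccccc1`, which also bears 2,4,5-trimethoxyphenyl and gives 7630 nM in this assay. On that single value, at best a modest gain in strength is expected, and a report of only a limit is about as likely as a number. The expected size is an at least 1.2-fold lower number from compound 3 to compound 4 (0.09 log units; that floor lies within the scatter). Compound 4 is estimated at 8000 nM, with an expected range from 3500 nM to 16000 nM.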

Compound 4, half-maximal inhibitory concentration: > 10000 nM
Compound 4: no number, only a limit; the forecaster's own chance of this, stated with the estimate: 50%; at least 1.2-fold (0.09 log units) between middle value and limit.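

In this assay compound 4 is reported only as a limit, > 10000 nM, not as a number. Thus, methoxy in place of hydrogen on compound 3, which gives 2,4,5-trimethoxyphenyl, yields no number for the chloro compounds, and the steps into compound 4 from compound 2 and compound 3 cannot be read. With 2,4,5-trimethoxyphenyl held fixed, the one readable change, chloro in place of hydrogen, gives an at least 1.3-fold higher number from compound 1 to compound 4 (0.11 log units; that floor lies within the scatter), and the set now gathers at one limit: the limit of > 10000 nM in this assay, at which 3 of the 4 values shown sit.

From the compounds shown here alone, the true size of that chloro step remains open, as does any difference among the three methoxy patterns of compound 2, compound 3 and compound 4. Also open, going by these compounds, is whether an amine or a carboxylic acid in place of the chloro group would give a number in this assay.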